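Demethylation on the benzoyl ring of two benzofuran ketones

The source may hold more compounds than are shown below. What is called first, only, known or untested is meant among the compounds shown, and "the series" means these compounds.

Compound 1 `CCc1oc2ccc(OC)cc2c1C(=O)c1ccc(OC)cc1`: 24.3%
Compound 2 `CCc1oc2ccc(O)cc2c1C(=O)c1ccc(OC)cc1`: 12.9%
Compound 3 `CCc1cc2c(C(=O)c3ccc(OC)cc3)c(O)ccc2o1`: 28.7%

Three measured compounds are compared in an assay for inhibition of solute carrier family 22 member 12 (Homo sapiens), read by scintillation counting, with a stated time of 60 min, tested at 50 uM; on this read-out lower numbers stand for less inhibition and higher numbers for more inhibition at the one concentration tested (going by the name of the read-out). Compound 1 `CCc1oc2ccc(OC)cc2c1C(=O)c1ccc(OC)cc1` gives 24.3% in this assay. Compound 2 `CCc1oc2ccc(O)cc2c1C(=O)c1ccc(OC)cc1` differs from compound 1 by hydrogen in place of methyl on an oxygen on an aromatic ring; in this assay compound 2 gives 12.9%, and that step, a number 11.4 percentage points lower from compound 1 to compound 2 (beyond the scatter), lies beyond the scatter. Compound 3 `CCc1cc2c(C(=O)c3ccc(OC)cc3)c(O)ccc2o1` gives 28.7% in this assay; how its core differs from that of compound 1 is not broken down here, and the values of compound 3 and compound 1 lie within the scatter of each other, while compound 2 sits beyond the scatter below compound 3.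

Compound 4 `CCc1cc2c(C(=O)c3ccc(O)cc3)c(O)ccc2o1` has not yet been measured. It differs from compound 3 by hydrogen in place of methyl on an oxygen on an aromatic ring, the same change as from compound 1 to compound 2, placed on an oxygen whose other neighbour is an aromatic carbon in both cases. Since this change lowered the read-out once, as a number 11.4 percentage points lower from compound 1 to compound 2 (beyond the scatter) shows, a step of similar size is expected here, a number 11.7 percentage points lower from compound 3 to compound 4 (beyond the scatter), though the core of compound 3 is not the same, so the step may not repeat exactly. Compound 4 is therefore estimated at 17% in this assay, with a likely range from 5% to 30%.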

Compound 4, a percentage reported as inhibition, at one concentration (the size of the read-out at that concentration, not a potency): 51.5%
The estimate for compound 4 lay 34.5 percentage points below the measured number; measured number above the stated range.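

In this assay, the change from methoxy to hydroxy on the core of compound 3 gave a number 22.8 percentage points higher from compound 3 to compound 4 (beyond the scatter), so the effect seen on the core of compound 1 did not carry over in either direction or size: the same change on two cores in this assay, a number 11.4 percentage points lower (beyond the scatter) from compound 1 to compound 2 and a number 22.8 percentage points higher (beyond the scatter) from compound 3 to compound 4, 34.2 percentage points apart, beyond the scatter of two such steps Within this series, then, the result of this change cannot be read from one core to the other, and a single earlier step is a poor guide to the next. The two steps do not show why they part, whether the difference comes from the cores themselves or from which methoxy is changed, and two pairs give no rule for any further core.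

The compounds shown leave open how either core would respond to a longer chain on that oxygen, such as ethoxy, or to a carboxylic acid in place of the hydroxy. From the compounds shown here alone, it also remains open whether an amine there would follow the step seen on the core of compound 1 or the one on the core of compound 3.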